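Amide substituent variation on a shared core

A few compounds are considered here, and "the series" means these few. Any claim that something is new, unique, unknown or untested is made for them only; others in the source may bear on it.

Measured compounds:
compound 1 `COc1cc(-n2cccc2C(=O)N2CCCCC2)ccc1Nc1ncc(Cl)c(Nc2ccccc2NS(C)(=O)=O)n1` — 1040 nM
compound 2 `CCN1CCN(C(=O)c2cccn2-c2ccc(Nc3ncc(Cl)c(Nc4ccccc4NS(C)(=O)=O)n3)c(OC)c2)CC1` — 1410 nM

In a functional assay on KARPAS-299 cells (Homo sapiens) for antiproliferative activity, read by MTT assay, with a stated time of 4 h (a lower number here means a stronger inhibitor, a higher number a weaker inhibitor), compound 1 gives 1040 nM, the lower of the two numbers; the step of a 1.4-fold higher number from compound 1 to compound 2 (0.13 log units; within the scatter) is within the scatter, so compound 1 and compound 2, which gives 1410 nM, are not separated by more than repeat measurements would show. Compound 2 replaces the piperidin-1-yl of compound 1 on the carbonyl carbon with 4-ethylpiperazin-1-yl.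

Compound 3 `COc1cc(-n2cccc2C(=O)N2CC(O)C2)ccc1Nc1ncc(Cl)c(Nc2ccccc2NS(C)(=O)=O)n1` has not been measured. It differs from compound 1 as follows: 3-hydroxyazetidin-1-yl in place of piperidin-1-yl on a carbonyl carbon

Among the compounds with values here, the only measured step that bears on this change is the one from compound 1 to compound 2, which also exchanges the group on the carbonyl carbon and stays within the scatter. Nothing measured speaks to the hydrogen-bond donor that enters with 3-hydroxyazetidin-1-yl, so no direction can be read from the data. For compound 3 the expected step is a 1.1-fold higher number from compound 1 to compound 3 (0.02 log units; within the scatter), nothing beyond the scatter. Compound 3 is therefore estimated to give about 1100 nM, with a range from 450 nM to 2700 nM.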

Compound 3, half-maximal inhibitory concentration: 81 nM
Compound 3: the middle estimate sits 14-fold (1.13 log units) above what was measured; measured number outside the range, below it.
By their numbers in this assay, from the lowest: compound 3; then compounds 1 and 2 (each within the scatter of the next).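

The group on the carbonyl carbon is not indifferent to the result: in this assay, 3-hydroxyazetidin-1-yl in place of piperidin-1-yl gives a 13-fold lower number from compound 1 to compound 3 (1.11 log units; beyond the scatter), and the same group in place of 4-ethylpiperazin-1-yl gives a 17-fold lower number from compound 2 to compound 3 (1.24 log units; beyond the scatter), whereas the exchange between the two six-membered rings had stayed within the scatter. The change that separates compound 3 from the other two swaps a six-membered ring for a four-membered one and also brings in a hydroxyl group, so ring size and the hydroxyl group change together in both steps. No measurement at hand gives a reason for either step.

The compounds shown leave open whether the step follows the four-membered ring or the hydroxyl group, a question that azetidin-1-yl and 4-hydroxypiperidin-1-yl on the same carbonyl carbon would separate. They also leave open whether the hydroxyl group can be exchanged within the four-membered ring, as in 3-methoxyazetidin-1-yl or 3-aminoazetidin-1-yl, and whether a five-membered ring such as 3-hydroxypyrrolidin-1-yl would fall with compound 3 or with compound 1.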